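The source may report more compounds than this note shows. Statements on the series, on what has been measured and on what is new or still open speak of the compounds shown alone.

Compound 1 `Cc1ccc(C(=O)OC2CCN(C)CC2)cc1`: 1.17
Compound 2 `Cc1ccc(C)c(C(=O)OC2CCN(C)CC2)c1`: 1.36
Compound 3 `CN1CCC(OC(=O)c2ccccc2C(F)(F)F)CC1`: 1.49

These three compounds share one core and were tested in a functional assay on the whole organism with Mus musculus as the target; on this read-out lower numbers stand for lower potency and higher numbers for higher potency (the scale is a negative logarithm). Among the three numbers, compound 1 gives the lowest, 1.17. Among the compounds with values here, the nearest is compound 2, whose number lies within the usual scatter of the one for compound 1, so the two cannot be told apart. The number for compound 3 stands further off, beyond the scatter, so compound 3 reads as more potent than compound 1.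

Compound 4 `CN1CCC(OC(=O)c2ccc([N+](=O)[O-])cc2)CC1` has not yet been measured in this assay. It differs from compound 1 in one place: nitro in place of methyl on an aromatic carbon. Within the data shown here, no directly comparable pair has been measured, so the size of this step can only be guessed. Given how closely the three measured numbers sit, a modest step is expected, and it is estimated as a number 0.13 log units higher from compound 1 to compound 4 (within the scatter). Compound 4 is therefore expected to give about 1.3 in this assay, with a likely range from 0.85 to 1.75.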

Compound 4, logarithm of the reciprocal of the active concentration, log(1/C): 1.14
Compound 4: middle estimate off by 0.16 log units, on the high side, and the stated range covers the measured number.
By their numbers in this assay, from the lowest: compounds 4, 1, 2 and 3 (each within the scatter of the next, the first and the last beyond it).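

In this assay, nitro in place of methyl on an aromatic carbon, para to a large group, gives a number 0.03 log units lower from compound 1 to compound 4 (within the scatter) and so leaves the two compounds indistinguishable. This is the only pair shown that differs in one place, and it gives the first direct reading at this position: a group of three heavy atoms with two hydrogen-bond acceptors replaces a single carbon with no hydrogen-bond acceptors, yet the read-out does not separate them. Nothing available explains why these two groups read alike.

As far as these compounds go, whether an amine, a carboxylic acid or a longer chain at this same position would shift the number beyond the scatter remains open. From the compounds shown here alone, it is also open whether swapping methyl for nitro elsewhere on the aromatic ring would give an equally small step.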